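The source may report more compounds than this note shows. Statements on the series, on what has been measured and on what is new or still open speak of the compounds shown alone.

Measured in a functional assay on HeLa cells (Homo sapiens) for antiproliferative activity, read by MTT assay, with a stated time of 48 h; on this read-out lower numbers stand for stronger inhibition of growth and higher numbers for weaker inhibition of growth:
- Compound 1 `COC(=O)N1N=C(c2ccccc2)CC1c1cc(OC)c(OC)c(OC)c1`: 2180 nM
- Compound 2 `COC(=O)N1N=C(c2cccc(OC)c2)CC1c1cc(OC)c(OC)c(OC)c1`: 1530 nM
- Compound 3 `COC(=O)N1N=C(c2ccc(OC)cc2)CC1c1cc(OC)c(OC)c(OC)c1`: 2590 nM

Compound 3, at 2590 nM, lies within the scatter of both other compounds, so these three cannot be ranked in this assay. Compound 4 `CCOc1cccc(C2=NN(C(=O)OC)C(c3cc(OC)c(OC)c(OC)c3)C2)c1` differs from compound 3 at one place: 3-ethoxyphenyl in place of 4-methoxyphenyl on a carbon with a double bond to nitrogen.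

Among the measured compounds shown here, three measured steps bear on this change. Methoxy in place of hydrogen on an aromatic carbon gave a 1.4-fold lower number from compound 1 to compound 2 (0.15 log units; within the scatter) and a 1.2-fold higher number from compound 1 to compound 3 (0.07 log units; within the scatter). Putting 4-methoxyphenyl in place of 3-methoxyphenyl gave a 1.7-fold higher number from compound 2 to compound 3 (0.23 log units; within the scatter). For the measured compounds named here, all three are small, although no measured compound carries an ethoxy group, so that part of the change is untested. The nearest guide is compound 2, which carries 3-methoxyphenyl and gives 1530 nM. A step beyond the scatter is therefore not expected, and the estimated step is a 1.4-fold lower number from compound 3 to compound 4 (0.16 log units; within the scatter). For compound 4 the estimated value is 1800 nM, with an expected range from 900 nM to 3600 nM.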

Compound 4, concentration for 50% growth inhibition: 4970 nM
Compound 4: middle estimate off by 2.8-fold (0.44 log units), on the low side, outside the stated range (above it).
By their numbers in this assay, from the lowest: compounds 2, 1, 3 and 4 (each within the scatter of the next, the first and the last beyond it).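

In this assay, among the compounds shown here, this ring had so far taken a methoxy group with every step inside the scatter, but 3-ethoxyphenyl brings the first steps beyond it: adding ethoxy in place of hydrogen gives a 2.3-fold higher number from compound 1 to compound 4 (0.36 log units; beyond the scatter) and adding one methyl to the 3-methoxy group gives a 3.2-fold higher number from compound 2 to compound 4 (0.51 log units; beyond the scatter), both meaning weaker inhibition of growth. Against the 4-methoxyphenyl group the change stays small, with a 1.9-fold higher number from compound 3 to compound 4 (0.28 log units; within the scatter), so the weakening is clear only against compound 1 and compound 2. Nothing shown here explains why so small an addition weakens inhibition.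

The compounds shown leave open whether a longer chain such as propoxy would raise the number further, and how a hydroxy group or an amine would behave on this ring. They also leave open how 4-ethoxyphenyl would compare with 3-ethoxyphenyl.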